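Trifluoromethylphenyl replacing the indolyl on the shared core

The source may report more compounds than this note shows. Statements on the series, on what has been measured and on what is new or still open speak of the compounds shown alone.

Compound 1, `COc1cc(-c2ccnc3cc(-c4ccc(C(C)=O)cc4)nn23)cc(OC)c1OC`: 5230 nM
Compound 2, `COc1cc(-c2ccnc3cc(-c4ccc5ccn(C)c5c4)nn23)cc(OC)c1OC`: 74 nM
Compound 3, `COc1cc(-c2ccnc3cc(-c4ccc5c(ccn5C)c4)nn23)cc(OC)c1OC`: 3 nM

The three measured compounds share the core of compound 1 and differ only in the aryl group on the aromatic carbon of the fused five-membered ring. In a functional assay on MCF7 cells (Homo sapiens) for inhibition, read by CCK-8 assay, with a stated time of 48 h (a lower number here means a stronger inhibitor, a higher number a weaker inhibitor), compound 3 gives the lowest number of the three: a 25-fold lower number from compound 2 to compound 3 (1.39 log units; beyond the scatter) and a 1700-fold lower number from compound 1 to compound 3 (3.24 log units; beyond the scatter) both lie beyond the scatter, so compound 3 is the strongest inhibitor shown.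

Compound 4, `COc1cc(-c2ccnc3cc(-c4ccc(C(F)(F)F)cc4)nn23)cc(OC)c1OC`, has not yet been measured. It differs from compound 3 in one place: 4-(trifluoromethyl)phenyl in place of 1-methyl-1H-indol-5-yl on an aromatic carbon. Within the data shown here, no measured step carries this exact change, but the step of a 1700-fold lower number from compound 1 to compound 3 (3.24 log units; beyond the scatter) bears on it, as compound 1 also carries a phenyl bearing a single substituent in place of the indolyl. The step of a 71-fold lower number from compound 1 to compound 2 (1.85 log units; beyond the scatter) shows that the direction of the change matters less than the presence of the indolyl itself. Compound 4 is therefore expected to give a much higher number in this assay than compound 3, a step of about a 1000-fold higher number from compound 3 to compound 4 (3.00 log units; beyond the scatter). The estimate for compound 4 is 3000 nM, with a range from 500 nM to 15000 nM.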

Compound 4, half-maximal inhibitory concentration: 2440 nM
The estimate for compound 4 lay 1.2-fold (0.09 log units) above the measured number, within the range that was stated.
By their numbers in this assay, from the lowest: compound 3; then compound 2; then compound 4; then compound 1.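

In this assay, 4-(trifluoromethyl)phenyl at this position, on the aromatic carbon of the five-membered ring with 2 nitrogen, stands far from both indolyl groups, with an 810-fold higher number from compound 3 to compound 4 (2.91 log units; beyond the scatter) and a 33-fold higher number from compound 2 to compound 4 (1.52 log units; beyond the scatter). Trifluoromethyl in place of acetyl on the phenyl shifts the number only modestly, with a 2.1-fold lower number from compound 1 to compound 4 (0.33 log units; beyond the scatter), so compound 1 and compound 4 lie close together and well apart from compound 2 and compound 3. The high number of compound 1 is therefore not confined to its acetyl group, since a second phenyl bearing a single substituent also gives a much higher number than either indolyl compound, although nothing given here explains the gap.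

The compounds shown leave open whether any substituent on this phenyl could close that gap, such as an amine, a hydroxyl or a carboxylic acid. They also leave open how much of the low number of compound 3 depends on the methyl on the indole nitrogen, and whether an unsubstituted 1H-indol-5-yl or a longer chain on that nitrogen would hold it.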